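The source may hold more compounds than are shown below. What is called first, only, known or untested is meant among the compounds shown, and "the series" means these compounds.

Measured compounds:
compound 1 `Cn1nc(-c2ccnc(Nc3ccc(O)cc3)n2)c2ccccc21` — 8910 nM
compound 2 `Cc1cccc(Nc2nccc(-c3nn(C)c4ccccc34)n2)c1` — 9150 nM

In a functional assay on MCF7 cells (Homo sapiens) for antiproliferative activity, read by MTT assay, with a stated time of 72 h (on this read-out higher numbers stand for weaker inhibition of growth and lower numbers for stronger inhibition of growth), compound 1 gives 8910 nM, and compound 2 gives 9150 nM. The step of a 1.0-fold higher number from compound 1 to compound 2 (0.01 log units; within the scatter) is within the scatter, so compound 1 and compound 2 cannot be told apart on these numbers. Compound 3 `CCCn1nc(-c2ccnc(Nc3ccc(O)cc3)n2)c2ccccc21` differs from compound 1 by ethyl in place of hydrogen on a saturated chain carbon bound to an aromatic nitrogen. Among the compounds with values here, no measured step touches this position; the only measured step concerns a different part of the shared core, so it gives no guide to the size of the change. Compound 3 is therefore expected to show a 1.0-fold lower number from compound 1 to compound 3 (0.02 log units; within the scatter), which amounts to no step beyond the scatter. The estimate for compound 3 is 8500 nM, with a range from 3000 nM to 25000 nM.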

Compound 3, concentration for 50% growth inhibition: 3340 nM
Estimate against measurement, compound 3: 2.5-fold (0.41 log units) above; measured number inside the range.
By their numbers in this assay, from the lowest: compound 3; then compounds 1 and 2 (each within the scatter of the next).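

In this assay, within the data shown here, the substituent on the aromatic nitrogen is the first place in this set where a change moves the number beyond the scatter: going from methyl to propyl gives a modest step (a 2.7-fold lower number from compound 1 to compound 3 (0.43 log units; beyond the scatter)), toward stronger inhibition of growth. The earlier step, in a different part of the shared core, stayed within the scatter. Nothing measured here explains this gain.

Going by these compounds, whether a longer chain or a chain ending in an amine would lower the number further remains open. So does whether propyl would give a similar step alongside the 3-methylphenyl group of compound 2.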